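Compound 3 to compound 4: a swapped aryl group

The source may report more compounds than this note shows. Statements on the series, on what has been measured and on what is new or still open speak of the compounds shown alone.

In a functional assay on A549 cells (Homo sapiens) for cytotoxicity, read by MTT assay, with a stated time of 72 h (on this read-out lower numbers stand for stronger inhibition and higher numbers for weaker inhibition), compound 1 (`COc1ccc(/C=C2\CCC/C(=C\c3ccc(Cl)cc3)C2=O)cc1OC`) gives 10100 nM and compound 2 (`COc1ccc(/C=C2\CCC/C(=C\c3ccc(Br)cc3)C2=O)cc1OC`) gives 16000 nM. Between these two lies a 1.6-fold higher number from compound 1 to compound 2 (0.20 log units; within the scatter).

Compound 3 (`COc1ccccc1/C=C1\CCC/C(=C\c2ccc(OC)c(OC)c2)C1=O`) gives > 20000 nM, which is a limit of the assay and not a number. Compound 3 therefore stands at the limit of > 20000 nM in this assay, at which 1 of the 3 values shown sits.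

The next structure is compound 4 (`COc1ccc(/C=C2\CCC/C(=C\c3cccc(O)c3)C2=O)cc1OC`), with 3-hydroxyphenyl in place of 2-methoxyphenyl on a double-bonded chain carbon bound to a double-bonded ring carbon.

Within the data shown here, two measured steps touch the same place: an at least 1.9-fold higher number from compound 1 to compound 3 (0.29 log units; that floor lies within the scatter), and an at least 1.2-fold higher number from compound 2 to compound 3 (0.09 log units; that floor lies within the scatter). Both give only floors, and neither goes beyond the scatter. Among the measured compounds shown here, no measured compound carries 3-hydroxyphenyl, so these steps set no firm direction for the new group.

The expectation in this assay is therefore no clear step beyond the scatter, with a slight lean towards a lower number, as compound 1 gave 10100 nM and compound 2 gave 16000 nM. The step expected here is an at least 1.3-fold lower number from compound 3 to compound 4 (0.12 log units; that floor lies within the scatter). For compound 4 the estimated value is 15000 nM, with an expected range from 6000 nM to 30000 nM.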

Compound 4, half-maximal inhibitory concentration: 4300 nM
Compound 4: middle estimate off by 3.5-fold (0.54 log units), on the high side; the whole stated range lies above it.
By their numbers in this assay, from the lowest: compound 4; then compounds 1 and 2 (each within the scatter of the next). At a limit, above all of these: compound 3.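

In this assay, among these compounds, the place on a double-bonded chain carbon bound to a double-bonded ring carbon now gives steps beyond the scatter, which none of the earlier pairs did: 3-hydroxyphenyl in place of 4-chlorophenyl gives a 2.3-fold lower number from compound 1 to compound 4 (0.37 log units; beyond the scatter), and 3-hydroxyphenyl in place of 4-bromophenyl gives a 3.7-fold lower number from compound 2 to compound 4 (0.57 log units; beyond the scatter). Against 2-methoxyphenyl, the change, which brings in a group with 1 hydrogen-bond donor for one with 0, gives an at least 4.6-fold lower number from compound 3 to compound 4 (0.66 log units; beyond the scatter). Compound 3 sits at a limit of the assay and not at a number, so this last step is a floor and its true size stays unknown: the limit of > 20000 nM in this assay, at which 1 of the 4 values shown sits.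

Still open, as far as these compounds go, is whether the lower number follows the hydroxyl itself or the place it holds on the aromatic ring; a 3-methoxyphenyl or a 4-hydroxyphenyl group at this carbon would separate the two. Also open, from the compounds shown here alone, is whether an amine, as in 3-aminophenyl, would give a comparable number, and whether the step carries over to other cell lines.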